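Replacing 4-nitrophenyl with 2-methylphenyl in compound 3

A few compounds are considered here, and "the series" means these few. Any claim that something is new, unique, unknown or untested is made for them only; others in the source may bear on it.

Compound 1 `CCCCCCCCCCCCCCNC(=O)[C@H](CO)/N=C/c1cccc(OC)c1`: 77300 nM
Compound 2 `CCCCCCCCCCCCCCNC(=O)[C@H](CO)/N=C/c1ccccc1Cl`: 94900 nM
Compound 3 `CCCCCCCCCCCCCCNC(=O)[C@H](CO)/N=C/c1ccc([N+](=O)[O-])cc1`: 49500 nM

In an ADME assay on HEK293 cells (Homo sapiens) for cytotoxicity (a higher number here means a weaker inhibitor, a lower number a stronger inhibitor), compound 3 gives 49500 nM, which stands within the scatter of the other two compounds: a 1.6-fold lower number from compound 1 to compound 3 (0.19 log units; within the scatter) and a 1.9-fold lower number from compound 2 to compound 3 (0.28 log units; within the scatter). Compound 4 `CCCCCCCCCCCCCCNC(=O)[C@H](CO)/N=C/c1ccccc1C` differs from compound 3 in one place: 2-methylphenyl in place of 4-nitrophenyl on a carbon with a double bond to nitrogen. Its 2-methylphenyl group replaces 4-nitrophenyl on a carbon with a double bond to nitrogen. All three measured exchanges of this group, including a 1.2-fold higher number from compound 1 to compound 2 (0.09 log units; within the scatter), stayed within the scatter, so no larger step is expected here. The expected step is small, a 1.5-fold higher number from compound 3 to compound 4 (0.18 log units; within the scatter), and does not go beyond the scatter. For compound 4 the estimated value is 75000 nM, with an expected range of 40000 nM to 130000 nM.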

Compound 4, half-maximal inhibitory concentration: 81100 nM
Beside the measured number, compound 4's estimate is 1.1-fold (0.03 log units) below it; low and high end bracket the measured number.
By their numbers in this assay, from the lowest: compounds 3, 1, 4 and 2 (each within the scatter of the next).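

In this assay, 2-methylphenyl in place of 4-nitrophenyl, which removes the hydrogen-bond acceptors of that group, gives a step within the scatter (a 1.6-fold higher number from compound 3 to compound 4 (0.21 log units; within the scatter)). The same holds for methyl in place of chloro on an aromatic carbon (a 1.2-fold lower number from compound 2 to compound 4 (0.07 log units; within the scatter)) and for 2-methylphenyl in place of 3-methoxyphenyl (a 1.0-fold higher number from compound 1 to compound 4 (0.02 log units; within the scatter)), so all six exchanges among these four compounds lie within the scatter. No measurement at hand explains this. As far as these compounds go, whether an amine or a carboxylic acid on this aromatic ring would give a step beyond the scatter remains open.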